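Replacing the phenyl of compound 3

The source may report more compounds than this note shows. Statements on the series, on what has been measured and on what is new or still open speak of the compounds shown alone.

Compound 1 `COc1ccc(C2=C(c3cc(OC)c(OC)c(OC)c3)C(=O)CC2O[SiH2]C(C)(C)C)cc1` in an ADME assay on KB cells (Homo sapiens) for cytotoxicity, read by MTT assay, with a stated time of 72 h; on this read-out lower numbers stand for stronger inhibition and higher numbers for weaker inhibition: > 100 ug/mL (a limit)
Compound 2 `COc1ccc(OC)c(C2=C(c3cc(OC)c(OC)c(OC)c3)C(=O)CC2O[SiH2]C(C)(C)C)c1` in this assay: 10 ug/mL
Compound 3 `COc1cc(C2=C(c3ccccc3)C(O[SiH2]C(C)(C)C)CC2=O)cc(OC)c1OC` in this assay: > 100 ug/mL (a limit)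

Compound 3 stands at > 100 ug/mL, which is a limit of this assay and not a number. Compound 1 stands at > 100 ug/mL, which is also a limit. Only compound 2 has a true number, 10 ug/mL.

Compound 4 `COCOc1cc(C2=C(c3cc(OC)c(OC)c(OC)c3)C(=O)CC2O[SiH2]C(C)(C)C)ccc1OC` has yet to be measured. In it, 4-methoxy-3-(methoxymethoxy)phenyl comes in place of phenyl on a double-bonded ring carbon (4-methoxy-3-(methoxymethoxy)phenyl in place of phenyl on a double-bonded ring carbon).

Among the compounds with values here, two measured steps concern this same group. One is an at least 10-fold lower number from compound 1 to compound 2 (1.00 log units; beyond the scatter), with 2,5-dimethoxyphenyl in place of 4-methoxyphenyl. The other is an at least 10-fold higher number from compound 2 to compound 3 (1.00 log units; beyond the scatter), with phenyl in place of 2,5-dimethoxyphenyl. The third, a step that the two limits leave unreadable from compound 1 to compound 3, adds nothing on size.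

Compound 2 at 10 ug/mL suggests that a more substituted aryl group can lower the number, so a modest move in that direction is expected. Compound 4 may nevertheless remain at the limit, as compound 1 did with its 4-methoxyphenyl. The expected step is an at least 4.0-fold lower number from compound 3 to compound 4 (0.60 log units; beyond the scatter). For compound 4 the estimated value is 25 ug/mL, with an expected range from 5 ug/mL to 100 ug/mL.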

Compound 4, half-maximal inhibitory concentration: 33 ug/mL
Compound 4: middle estimate off by 1.3-fold (0.12 log units), on the low side; low and high end bracket the measured number.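

In this assay, 4-methoxy-3-(methoxymethoxy)phenyl on the double-bonded ring carbon gives a readable number where phenyl does not, with an at least 3.0-fold lower number from compound 3 to compound 4 (0.48 log units; beyond the scatter), and methoxymethoxy in place of hydrogen on an aromatic carbon gives an at least 3.0-fold lower number from compound 1 to compound 4 (0.48 log units; beyond the scatter). Compound 1 and compound 3 each stand at a limit and not a number, so both of these steps have only a lower bound on their size: the limit of > 100 ug/mL in this assay, at which 2 of the 4 values shown sit. Compound 2 and compound 4 both carry oxygen groups on this aromatic ring and both give true numbers, a pattern that compound 1 goes against, and the two arrangements are not equal, with a 3.3-fold higher number from compound 2 to compound 4 (0.52 log units; beyond the scatter).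

The compounds shown leave open whether a free hydroxyl in place of the methoxymethoxy would read differently, and whether an amine or a carboxylic acid on this aromatic ring would move the number further. Also open, as far as these compounds go, are the true values behind the limits of compound 1 and compound 3, and whether the silyl ether shared by all four compounds takes any part in these numbers.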